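Benzyl in place of 1-phenylethyl on a shared core

This account rests on a few compounds, and the source may have more. Where it says the series, first, only, none or still open, it means among the compounds named here.

Measured in a functional assay on A549 cells (Homo sapiens) for cytotoxicity, read by MTT assay, with a stated time of 72 h (a higher number here means a weaker inhibitor, a lower number a stronger inhibitor), so far:
- compound 1 `CCCOCNc1n[n+]([O-])c2cc(OC)ccc2[n+]1[O-]`: 2810 nM
- compound 2 `COc1ccc2c(c1)[n+]([O-])nc(NCOC(C)c1ccccc1)[n+]2[O-]`: 3130 nM
- compound 3 `[O-][n+]1nc(NCOC2CCCCC2)[n+]([O-])c2ccccc21`: 5180 nM

In this assay compound 2 gives the second highest of the three numbers. Among the measured compounds shown here, its nearest neighbour is compound 1, and the one step measured between two compounds that differ in one place, a 1.1-fold higher number from compound 1 to compound 2 (0.05 log units; within the scatter), lies within the scatter. Compound 3 differs from compound 2 in more than one place, so its value can only be set beside the others; the gap between them is also within the scatter.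

Compound 4 `COc1ccc2c(c1)[n+]([O-])nc(NCOCc1ccccc1)[n+]2[O-]` is not yet measured. It differs from compound 2 as follows: hydrogen in place of methyl on a saturated chain carbon bound to an aromatic carbon and an oxygen on a saturated carbon. Cut one bond further out, the same difference reads 1-phenylethyl to benzyl. For the measured compounds named here, the only step that bears on it is the one from compound 1 to compound 2, a change on the same oxygen on a saturated carbon, and it did not move the number beyond the scatter. Removing one carbon from that group is therefore expected to give a step of about a 1.0-fold higher number from compound 2 to compound 4 (0.01 log units; within the scatter), with no direction beyond the scatter. Compound 4 is estimated at 3200 nM, within 1500 nM to 6800 nM.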

Compound 4, half-maximal inhibitory concentration: 2500 nM
The estimate for compound 4 lay 1.3-fold (0.11 log units) above the measured number; measured number inside the range.
By their numbers in this assay, from the lowest: compounds 4, 1, 2 and 3 (each within the scatter of the next, the first and the last beyond it).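

In this assay, hydrogen can replace the methyl on the saturated chain carbon bound to an aromatic carbon and an oxygen on a saturated carbon without moving the number beyond the scatter (a 1.3-fold lower number from compound 2 to compound 4 (0.10 log units; within the scatter)). The second new step, phenyl in place of ethyl on a saturated chain carbon bound to an oxygen on a saturated carbon, also stays within the scatter (a 1.1-fold lower number from compound 1 to compound 4 (0.05 log units; within the scatter)), so propyl, 1-phenylethyl and benzyl on this oxygen do not separate from one another on the shared core. No measurement at hand accounts for this lack of separation.

As far as these compounds go, the groups on this oxygen in these compounds are all built from carbon and hydrogen, so the effect of a chain ending in an amine or a carboxylic acid remains open. From the compounds shown here alone, whether any change at this position can move the number beyond the scatter also remains open.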